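This account rests on a few compounds, and the source may have more. Where it says the series, first, only, none or still open, it means among the compounds named here.

Measured so far:
compound 1 `CCOC(=O)c1cnc(NN2C(=O)C=C(c3ccccc3)C2=O)nc1C(F)(F)F`: 3700 nM
compound 2 `CCOC(=O)c1cnc(NN2C(=O)C=C(C)C2=O)nc1C`: 1900 nM

In a functional assay on Jurkat cells (Homo sapiens) for inhibition (a higher number here means a weaker inhibitor, a lower number a stronger inhibitor), compound 2 gives 1900 nM and compound 1 gives 3700 nM; the two values lie within the scatter of each other, so neither stands apart on this assay. Compound 3 `CCOC(=O)c1cnc(NN2C(=O)C=C(C)C2=O)nc1-c1cc2ccccc2s1` differs from compound 2 by 1-benzothiophen-2-yl in place of methyl on an aromatic carbon. For the measured compounds named here, no measured pair shows this kind of change, so the size of the step is open; no step beyond the scatter is expected, a small decrease at most. Compound 3 is estimated at 1300 nM (range 350 nM to 5000 nM), an expected step of a 1.5-fold lower number from compound 2 to compound 3 (0.16 log units; within the scatter).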

Compound 3, half-maximal inhibitory concentration: 800 nM
For compound 3 the middle estimate is 1.6-fold (0.21 log units) above the measured one, and the stated range covers the measured number.
By their numbers in this assay, from the lowest: compound 3; then compounds 2 and 1 (each within the scatter of the next).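

The methyl position on the shared core, next to the ring nitrogen and ortho to the ethoxycarbonyl group, accepts a far larger fused aromatic group without loss: in this assay the change to 1-benzothiophen-2-yl gives a 2.4-fold lower number from compound 2 to compound 3 (0.38 log units; beyond the scatter), a modest gain. For the compounds shown here, compounds 1 and 2 differ in more than one place, so only this pair isolates the position. No measurement on hand accounts for the gain. Still open, on these data alone, is whether phenyl or naphthalen-2-yl would do the same as 1-benzothiophen-2-yl. An amine or a carboxylic acid at this position also remains untested in the compounds shown here.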